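Swapping the aryl cap on compound 2's ring nitrogen

The source may hold more compounds than are shown below. What is called first, only, known or untested is meant among the compounds shown, and "the series" means these compounds.

Of the compounds shown here, three sharing one core have been tested in a functional assay on MGC-803 cells (Homo sapiens) for antiproliferative activity, read by CCK-8 assay, with a stated time of 72 h, tested at 8 uM; a higher number here means a stronger effect of the compound at the concentration tested, a lower number a weaker effect. Compound 1 `CN(C(=S)SCc1ccc(C(=O)Nc2ccccc2N)cc1)c1cccnc1` gives 82.5%, and compound 3 `Nc1ccccc1NC(=O)c1ccc(CSC(=S)N2CCCc3ccccc32)cc1` gives 87.5%; the change a number 5 percentage points higher from compound 1 to compound 3 (within the scatter) is within the scatter. Compound 2 `COc1ccc(N2CCN(C(=S)SCc3ccc(C(=O)Nc4ccccc4N)cc3)CC2)cc1` gives 22.9%, the lowest of the three numbers, far beyond the scatter from both compound 1 and compound 3.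

Compound 4 `Nc1ccccc1NC(=O)c1ccc(CSC(=S)N2CCN(c3ncccn3)CC2)cc1` is not yet measured. It differs from compound 2 as follows: pyrimidin-2-yl in place of 4-methoxyphenyl on an amine nitrogen in a ring. For the measured compounds named here, no measured step changes the group on this amine nitrogen in a ring; the only measured step, from compound 1 to compound 3, alters the group on the thiocarbonyl carbon and so does not bear directly on this change. Going by the values given here, the data therefore give no guide to direction or size, only that compound 2 starts from the low end.

For compound 4 the expected value in this assay is 35%, within a range from 10% to 70%. This estimate means an expected step of a number 12.1 percentage points higher from compound 2 to compound 4 (beyond the scatter), which is uncertain in both directions.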

Compound 4, a percentage reported as inhibition, at one concentration (the size of the read-out at that concentration, not a potency): 64.8%
Beside the measured number, compound 4's estimate is 29.8 percentage points below it; the measured number falls inside the stated range.
By their numbers in this assay, from the lowest: compound 2; then compound 4; then compounds 1 and 3 (each within the scatter of the next).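

In this assay, the group on this amine nitrogen in a ring strongly shapes the result: pyrimidin-2-yl in place of 4-methoxyphenyl gives a number 41.9 percentage points higher from compound 2 to compound 4 (beyond the scatter) in this single change. Compound 2 and compound 4 both carry the six-membered non-aromatic ring with 2 nitrogen. The low reading of compound 2 is not shared by compound 4, which carries that ring as well. Nothing available here explains why this swap has so large an effect.

From the compounds shown here alone, it remains open whether plain phenyl or pyridin-2-yl on the same nitrogen would read like compound 2 or like compound 4, and whether a simple methyl or acetyl group would do the same. A reading at one concentration also leaves the potency of both compounds undefined.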